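The source may hold more compounds than are shown below. What is called first, only, known or untested is meant among the compounds shown, and "the series" means these compounds.

Compounds measured so far:
compound 1, `Cc1ccc(S(=O)(=O)Oc2ccc3c(c2C)[C@H](Cn2cc(-c4ccccn4)nn2)[C@@]24CC(=O)[C@@](C)(CC[C@@H]32)C4)cc1`; compound 2, `Cc1c(O)ccc2c1[C@H](Cn1cc(-c3ccccn3)nn1)[C@@]13CC(=O)[C@@](C)(CC[C@@H]21)C3`; compound 3, `C=C1C(=O)[C@]23C[C@@]1(O)CC[C@H]2c1ccc(OS(=O)(=O)c2ccc(C)cc2)c(C)c1[C@@H]3Cn1cc(-c2ccc(C)cc2)nn1`.

In a functional assay on MCF7 cells (Homo sapiens) for cytotoxicity, read by MTT assay, with a stated time of 4 days (on this read-out higher numbers stand for weaker inhibition and lower numbers for stronger inhibition), compound 1 gives > 20000 nM, which is a limit of the assay and not a number. Compound 2 likewise gives > 20000 nM in this assay, again a limit. Compound 3 gives 320 nM in this assay. Within the data shown here, compound 1 therefore stands at the limit, with one further value also at that limit (the limit of > 20000 nM in this assay, at which 2 of the 3 values shown sit); the only step with a single change, a step that the two limits leave unreadable from compound 1 to compound 2, is not readable.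

Compound 4, `Cc1ccc(-c2cn(C[C@H]3c4c(ccc(OS(=O)(=O)c5ccc(C)cc5)c4C)[C@@H]4CC[C@@]5(C)C[C@]43CC5=O)nn2)cc1`, differs from compound 1 by 4-methylphenyl in place of pyridin-2-yl on an aromatic carbon. Among the measured compounds shown here, no measured step touches this change. For the measured compounds named here, compound 3 carries the same 4-methylphenyl group on the triazole and gives a number, but its core differs from that of compound 1 in more than one place, so it yields no step. The expectation for compound 4 is a move to a measurable value, expressed as an at least 3.3-fold lower number from compound 1 to compound 4 (0.52 log units; beyond the scatter), though a further limit cannot be ruled out. Compound 4 is estimated at 6000 nM, with a range from 1000 nM to 30000 nM.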

Compound 4, half-maximal inhibitory concentration: > 20000 nM
Compound 4 ended at the assay's limit (the forecaster's own chance of this, stated with the estimate: 45%); middle value at least 3.3-fold (0.52 log units) away from the limit.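

No step can be read between compound 1 and compound 4, as both values in this assay are limits and not numbers: the limit of > 20000 nM in this assay, at which 3 of the 4 values shown sit.

The compounds shown leave open whether 4-methylphenyl in place of pyridin-2-yl has any effect on a core giving numbers, and which structural difference goes with compound 3 at 320 nM.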